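Removal of the amino group from compound 3

The source may report more compounds than this note shows. Statements on the series, on what has been measured and on what is new or still open speak of the compounds shown alone.

Compound 1 `COc1ncnc2c1c(-c1ccsc1)cn2[C@@H]1O[C@H](CO)[C@@H](O)[C@H]1O` and compound 2 `COc1ncnc2c1c(-c1ccoc1)cn2[C@@H]1O[C@H](CO)[C@@H](O)[C@H]1O` carry no amino group on the shared core; in a functional assay on K562 cells (Homo sapiens), read by MTT assay, with a stated time of 72 h (on this read-out lower numbers stand for stronger inhibition and higher numbers for weaker inhibition), compound 1 gives 3450 nM and compound 2 gives 2820 nM, and a 1.2-fold lower number from compound 1 to compound 2 (0.09 log units; within the scatter). Compound 3 `COc1nc(N)nc2c1c(-c1ccccc1)cn2[C@@H]1O[C@H](CO)[C@@H](O)[C@H]1O` carries the amino group and a phenyl group in place of the five-membered heteroaryl ring. For compound 3 this assay reports only a limit, > 20000 nM, so where it stands relative to compound 1 and compound 2 is not known beyond (the limit of > 20000 nM in this assay, at which 1 of the 3 values shown sits).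

Compound 4 `COc1ncnc2c1c(-c1ccccc1)cn2[C@@H]1O[C@H](CO)[C@@H](O)[C@H]1O` differs from compound 3 in one place: hydrogen in place of amino on an aromatic carbon. For the measured compounds named here, no measured step covers this change, and the step from compound 1 to compound 2 only shows that swapping the five-membered heteroaryl ring leaves the number within the scatter. Compound 4 thus shares the unsubstituted core of compound 1 and compound 2 with a phenyl group attached, and its number in this assay is expected to fall near theirs, 3500 nM with a range of 1200 nM to 12000 nM. The step from the limit of compound 3 to compound 4 is then estimated at an at least 5.7-fold lower number from compound 3 to compound 4 (0.75 log units; beyond the scatter), though the limit for compound 3 leaves its true size open.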

Compound 4, half-maximal inhibitory concentration: > 20000 nM
Compound 4: no number, only a limit (the forecaster's own chance of this, stated with the estimate: 12%); middle value at least 5.7-fold (0.75 log units) away from the limit.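

In this assay compound 4 gives > 20000 nM, which is a limit of the assay and not a number: the limit of > 20000 nM in this assay, at which 2 of the 4 values shown sit.

On the shared core without the amino group, the aryl group on the aromatic carbon now shows an effect: there is an at least 7.0-fold higher number from compound 2 to compound 4 (0.85 log units; beyond the scatter) and an at least 5.7-fold higher number from compound 1 to compound 4 (0.76 log units; beyond the scatter), whereas the earlier exchange of thiophen-3-yl for furan-3-yl gave only a 1.2-fold lower number from compound 1 to compound 2 (0.09 log units; within the scatter). Hydrogen in place of amino on the carbon between two ring nitrogen atoms leaves the phenyl compound at the limit, and the step between the two phenyl compounds cannot be read.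

On these data alone, how far compound 3 and compound 4 lie beyond the limit stays open, as does the effect of an amino group on the core carrying thiophen-3-yl or furan-3-yl. Also open, as far as these compounds go, is whether a pyridin-3-yl ring or a methyl group in place of phenyl would fall nearer compound 1 and compound 2.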